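This account rests on a few compounds, and the source may have more. Where it says the series, first, only, none or still open, it means among the compounds named here.

Series values in an ADME assay on HeLa cells (Homo sapiens) for cytotoxicity; on this read-out higher numbers stand for lower toxicity in this test and lower numbers for higher toxicity in this test:
- compound 1 `CCN(CC)CN1C(=O)/C(=N/NC(=S)Nc2ccccc2)c2cc(Cl)ccc21`: 13500 nM
- compound 2 `CCN(CC)CN1C(=O)/C(=N/NC(=S)Nc2ccc(Cl)cc2)c2ccccc21`: 9800 nM

Compound 2, at 9800 nM, lies within the usual scatter of compound 1, at 13500 nM. Within the data shown here, these two values are the only reference points, and no measured step between compounds differing in one place is available.

Next is compound 3 `CCN(CC)CN1C(=O)/C(=N/NC(=S)Nc2ccc(OC)cc2)c2ccccc21`, which has methoxy in place of chloro on an aromatic carbon, para to a large group: methoxy in place of chloro on an aromatic carbon. Among the measured compounds shown here, with no measured precedent for this change, no direction can be argued from the data. The expectation therefore stays anchored on compound 2 at 9800 nM. The expected 1.1-fold higher number from compound 2 to compound 3 (0.05 log units; within the scatter) is no larger than the scatter. In this assay, the estimate for compound 3 is 11000 nM, with an expected range of 4500 nM to 27000 nM.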

Compound 3, half-maximal cytotoxic concentration: > 100000 nM
Compound 3: only a limit was reported (the forecaster's own chance of this, stated with the estimate: 3%); middle value at least 9.0-fold (0.95 log units) away from the limit.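

In this assay, among these compounds, methoxy in place of chloro on an aromatic carbon, para to a large group, gives an at least 10-fold higher number from compound 2 to compound 3 (1.00 log units; beyond the scatter), the first single-place step. This position is therefore not indifferent to its substituent, and the exchange of chloro for methoxy is enough to move the read-out towards lower toxicity in this test. Compound 3 gives > 100000 nM, which is a limit of the assay and not a number, so the step has a floor but no measured size: the limit of > 100000 nM in this assay, at which 1 of the 3 values shown sits.

From the compounds shown here alone, it remains open whether this shift is specific to methoxy or would also follow from another group at this place, such as a hydroxyl, an amine or the longer ethoxy. Also open, going by these compounds, is whether methoxy would act the same way at the chloro-bearing site in the core of compound 1.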